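The source may report more compounds than this note shows. Statements on the series, on what has been measured and on what is new or still open speak of the compounds shown alone.

Measured compounds:
compound 1 `C=C(C)C(=O)N(Cc1ccc(OC)c(O)c1)c1cc(OC)c(OC)c(OC)c1` gives 200 nM in a functional assay on HCT-116 cells (Homo sapiens) for inhibition, read by MTT assay, with a stated time of 48 h; a lower number here means a stronger inhibitor, a higher number a weaker inhibitor;
compound 2 `COc1ccc(CN(C(=O)CCCCCl)c2cc(OC)c(OC)c(OC)c2)cc1O` gives 220 nM in this assay;
compound 3 `COc1ccc(CN(C(=O)C=C(C)C)c2cc(OC)c(OC)c(OC)c2)cc1O` gives 290 nM in this assay.

The three compounds share a core and differ only in the group attached to the carbonyl carbon of the amide. Within the data shown here, compound 3 has the highest of the three numbers, but its neighbours lie close: the step of a 1.3-fold higher number from compound 2 to compound 3 (0.12 log units; within the scatter) and the step of a 1.5-fold higher number from compound 1 to compound 3 (0.16 log units; within the scatter) are both within the scatter, as is a 1.1-fold higher number from compound 1 to compound 2 (0.04 log units; within the scatter), so no compound can be called stronger or weaker than another on these data.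

Compound 4 `CC/C=C/C(=O)N(Cc1ccc(OC)c(O)c1)c1cc(OC)c(OC)c(OC)c1` is not yet measured. It differs from compound 3 in one place: but-1-en-1-yl in place of 2-methylprop-1-en-1-yl on a carbonyl carbon.

Among the measured compounds shown here, every measured step so far swaps the group on the carbonyl carbon, and none of them moved the number beyond the scatter. The change to compound 4 is of the same kind, so no step beyond the scatter is expected in this assay either. For compound 4 the estimate is 270 nM, with a range from 130 nM to 600 nM; this estimate means a step of a 1.1-fold lower number from compound 3 to compound 4 (0.03 log units; within the scatter), expected to fall within the scatter.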

Compound 4, half-maximal inhibitory concentration: 63 nM
For compound 4 the middle estimate is 4.3-fold (0.63 log units) above the measured one, outside the stated range (below it).
By their numbers in this assay, from the lowest: compound 4; then compounds 1, 2 and 3 (each within the scatter of the next).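

In this assay the group on the carbonyl carbon can clearly affect the number: the change shows a 4.6-fold lower number from compound 3 to compound 4 (0.66 log units; beyond the scatter) even though the two groups contain the same atoms, joined differently. The other two steps, a 3.5-fold lower number from compound 2 to compound 4 (0.54 log units; beyond the scatter) and a 3.2-fold lower number from compound 1 to compound 4 (0.50 log units; beyond the scatter), are also beyond the scatter, which makes compound 4 the strongest inhibitor of these four and sets but-1-en-1-yl apart from the three earlier groups. Nothing available here explains why this rearrangement of the same atoms has such an effect.

Still open, as far as these compounds go, is whether the double bond matters, which a plain butyl group would test, and whether a longer chain such as pent-1-en-1-yl does as well as but-1-en-1-yl. A cyclopropyl group or a chain ending in an amine is also untested among the compounds shown.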